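The compounds below may be only part of what the source reports. "The series", "measured", "known", "first", "only" and "open" are said of these compounds alone.

Measured in a functional assay on HCT-116 cells (Homo sapiens) for inhibition, read by MTT assay, with a stated time of 48 h; on this read-out lower numbers stand for stronger inhibition and higher numbers for weaker inhibition:
- compound 1 `COc1ccc(CSc2nnc(-c3cc(OC)c(OC)c(OC)c3)n2-c2ccc(OC)cc2)cc1`: 49600 nM
- compound 2 `COc1ccc(-n2c(SCc3ccc(F)cc3)nnc2-c2cc(OC)c(OC)c(OC)c2)cc1`: 38700 nM
- compound 3 `COc1ccc(NC(=O)CSc2nnc(-c3cc(OC)c(OC)c(OC)c3)n2-c2ccc(OC)cc2)cc1`: > 60000 nM, a limit of the assay and not a number

Compound 3 stands only as a limit: the limit of > 60000 nM in this assay, at which 1 of the 3 values shown sits. No number is therefore available as a starting point for the next step.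

Compound 4 `COc1ccc(-n2c(SCC(=O)Nc3ccc(Cl)cc3)nnc2-c2cc(OC)c(OC)c(OC)c2)cc1` differs from compound 3 at one place, chloro in place of methoxy on an aromatic carbon, so that (4-methoxyphenyl)carbamoyl becomes (4-chlorophenyl)carbamoyl.

The closest measured swap is a 1.3-fold lower number from compound 1 to compound 2 (0.11 log units; within the scatter), which also replaces methoxy on an aromatic carbon, though with fluoro and on a compound without the carbamoyl. It gives no sign of a real shift. The two steps that introduce the carbamoyl, an at least 1.2-fold higher number from compound 1 to compound 3 (0.08 log units; that floor lies within the scatter) and an at least 1.5-fold higher number from compound 2 to compound 3 (0.19 log units; that floor lies within the scatter), are known only as floors. Among the measured compounds shown here, they fix no size, and none of the measured compounds carries chloro.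

On this basis no step beyond the scatter is expected in this assay, and a further limit remains a real possibility. The expected change is an at least 1.2-fold lower number from compound 3 to compound 4 (0.07 log units; that floor lies within the scatter). The estimated value for compound 4 is 50000 nM, with an expected range of 22000 nM to 90000 nM.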

Compound 4, half-maximal inhibitory concentration: > 60000 nM
Compound 4 gave a limit, no number; the forecaster's own chance of this, stated with the estimate: 45%; middle value at least 1.2-fold (0.07 log units) away from the limit.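

In this assay compound 4 ends at a limit of the assay and not at a number, as compound 3 does, so chloro in place of methoxy on this aromatic carbon brings no readable value, and the steps between limits cannot be read: the limit of > 60000 nM in this assay, at which 2 of the 4 values shown sit. With (4-chlorophenyl)carbamoyl on the saturated chain carbon bound to the sulfur, the comparison with the 4-fluorophenyl compound gives an at least 1.5-fold higher number from compound 2 to compound 4 (0.19 log units; that floor lies within the scatter), and the comparison with the 4-methoxyphenyl compound gives an at least 1.2-fold higher number from compound 1 to compound 4 (0.08 log units; that floor lies within the scatter). Both compounds with a carbamoyl now sit at the limit with either 4-methoxyphenyl or 4-chlorophenyl on the nitrogen, and no compound shown goes against this, though the two floors fix no size.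

On these data alone, whether the carbamoyl shifts the value beyond the scatter remains open, as only floors link it to compound 1 and compound 2. Also open, as far as these compounds go, is whether an amine or a carboxylic acid in place of chloro on that phenyl ring would give a number in this assay.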